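Methoxy added to a cyclobutyl amide: distribution in dog

The source may report more compounds than this note shows. Statements on the series, on what has been measured and on what is new or still open speak of the compounds shown alone.

Compound 1, `CCn1c(-c2ccc(C(F)(F)F)nc2)nc2c(O[C@H]3CCN(C(=O)N4CC(OC)C4)C3)ncnc21`: 1.7 L/kg
Compound 2, `CCn1c(-c2cnc(C)nc2)nc2c(O[C@H]3CCN(C(=O)C4CCC4)C3)ncnc21`: 1.4 L/kg
Compound 3, `CCn1c(-c2cnc(C)nc2)nc2c(N[C@H]3CCN(C(=O)N4CC(OC)C4)C3)ncnc21`: 1.9 L/kg

Of the compounds shown here, three on a shared core have been measured in an ADME assay (Canis lupus familiaris, strain Beagle) for pharmacokinetics; a lower number here means that more of the compound stays in the plasma, a higher number that more of the compound sits outside the plasma. Compound 2 gives 1.4 L/kg, while compound 1 gives 1.7 L/kg and compound 3 gives 1.9 L/kg. Both of the other numbers lie within the usual scatter of the number for compound 2, so the three compounds cannot be separated from one another on this assay: none of them stands apart.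

Compound 4, `CCn1c(-c2cnc(C)nc2)nc2c(O[C@H]3CCN(C(=O)[C@H]4C[C@@H](OC)C4)C3)ncnc21`, has not yet been measured in this assay. It is the partner of compound 2, and the difference between the two is methoxy in place of hydrogen on a saturated ring carbon. Cut one bond further out, this reads cyclobutyl to 3-methoxycyclobutyl.

Among the measured compounds shown here, no pair of measured compounds differs in only one place, so there is no measured step to lean on. Compound 1, which carries a methoxy on its own saturated ring, gives 1.7 L/kg, a number within the scatter of compound 2. On that basis the step from compound 2 to compound 4 is expected to be small, a 1.1-fold higher number from compound 2 to compound 4 (0.03 log units; within the scatter), not beyond the scatter in either direction. Compound 4 is therefore estimated at 1.5 L/kg, with a range from 1 L/kg to 2.3 L/kg.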

Compound 4, volume of distribution: 0.9 L/kg
Compound 4: middle estimate off by 1.7-fold (0.22 log units), on the high side, outside the stated range (below it).
By their numbers in this assay, from the lowest: compounds 4, 2, 1 and 3 (each within the scatter of the next, the first and the last beyond it).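

Among the compounds shown here, this is the first step in the set that changes one place only: in this assay methoxy in place of hydrogen on a saturated ring carbon of the four-membered ring gives a 1.6-fold lower number from compound 2 to compound 4 (0.19 log units; within the scatter) and no more. So at this place, two ring bonds from the ring atom that bears a large group, a methoxy can be carried without the two compounds coming apart on this measure, something the earlier compounds, with no one-place pair among them, could not show. The data given offer no explanation for the size of this step.

From the compounds shown here alone, a single step at a single ring carbon says little about other groups, and whether an amine, a carboxylic acid or a longer chain such as ethoxy at this place would carry the number beyond the scatter stays open. Also open, going by these compounds, is whether the other spatial arrangement of the methoxy on the four-membered ring, or the same change made on a compound that differs elsewhere, would read the same way.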